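Ester size at the limit of platelet inhibition

The compounds below may be only part of what the source reports. "The series", "measured", "known", "first", "only" and "open" are said of these compounds alone.

Values in a functional assay on cells (Platelet, Homo sapiens) for inhibition (on this read-out lower numbers stand for stronger inhibition and higher numbers for weaker inhibition), each one a limit:
- compound 1 `CCOC(=O)c1cccc(-c2n[nH]c3ccccc23)c1`: > 10000 nM
- compound 2 `CCOC(=O)c1ccc(-c2nn(Cc3ccc(F)cc3)c3ccccc23)cc1`: > 10000 nM
- compound 3 `COC(=O)c1ccc(-c2nn(Cc3ccccc3)c3ccccc23)cc1`: > 10000 nM

Among the compounds with values here, all the measured compounds stand at one mark, (the limit of > 10000 nM in this assay, at which 3 of the 3 values shown sit), so the data hold no numerical value and no measured step. Compound 3 is known only by a limit, > 10000 nM, and not by a number. Compound 4 `CC(C)OC(=O)c1ccc(-c2nn(Cc3ccccc3)c3ccccc23)cc1` has isopropyl in place of methyl on an oxygen next to a carbonyl group and is otherwise the same. In this assay the expected change, a step that the limit leaves unreadable from compound 3 to compound 4, stays within the scatter, with no direction favoured. For compound 4 the estimated value is 15000 nM, with an expected range from 6000 nM to 40000 nM, and it will probably be reported as a limit again.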

Compound 4, half-maximal inhibitory concentration: > 10000 nM
Compound 4: only a limit was reported (the forecaster's own chance of this, stated with the estimate: 85%); the middle value is on the limit's open side.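

Compound 3 and compound 4 are both known only by a limit, so no step between them can be read: the limit of > 10000 nM in this assay, at which 4 of the 4 values shown sit.

The compounds shown leave open whether swapping methyl for isopropyl on the ester changes platelet inhibition at all.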